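A few compounds are considered here, and "the series" means these few. Any claim that something is new, unique, unknown or untested is made for them only; others in the source may bear on it.

The account follows the step from compound 1 `Cc1ccc2[nH]c(C)c(C(=O)NCc3ccc(N4CCC(c5ccc(OC(F)(F)F)cc5)CC4)cc3)c2c1` to compound 4 `Cc1nn2c(C)csc2c1C(=O)NCc1ccc(N2CCC(c3ccc(OC(F)(F)F)cc3)CC2)cc1`, a compound not yet tested. In a toxicity assay on Vero cells (Chlorocebus sabaeus) for cytotoxicity, read by CCK-8 assay, with a stated time of 72 h (on this read-out lower numbers stand for stronger inhibition and higher numbers for weaker inhibition), compound 1 has no result of its own; its entry reads "not determined" (no result reported), so compound 1 stands on no number here. Two related compounds share the same amide and the same piperidine-bearing tail. Compound 2 `Cc1cn2c(C(=O)NCc3ccc(N4CCC(c5ccc(OC(F)(F)F)cc5)CC4)cc3)c(C)nc2s1` gives in this assay only a limit of the assay, > 100000 nM, and not a number. Compound 3 `Cc1cn2nc(C)c(C(=O)NCc3ccc(N4CCC(c5ccc(OC(F)(F)F)cc5)CC4)cc3)c2s1` likewise gives in this assay only the limit > 100000 nM. The step between them, a step that the two limits leave unreadable from compound 2 to compound 3, cannot be read, because both values sit at the limit of > 100000 nM in this assay, at which 2 of the 3 values shown sit. Compound 4 differs from compound 1 by a group of 10 heavy atoms (7 carbon, 2 nitrogen, 1 sulfur; 2 five-membered aromatic rings with 2 hetero atoms each) in place of a group of 11 heavy atoms (10 carbon, 1 nitrogen; one five-membered aromatic ring with 1 hetero atom, one six-membered aromatic ring of carbon only), on a carbonyl carbon. Going by the values given here, no measured step bears directly on this change; what the numbers show is that two compounds whose entering group is made of the same atoms as that of compound 4 both give only the limit in this assay. Compound 4 is therefore expected to give only a limit as well. The estimate for compound 4 in this assay is 150000 nM, with a range from 50000 nM to 500000 nM.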

Compound 4, half-maximal inhibitory concentration: > 100000 nM
Compound 4: no number, only a limit (the forecaster's own chance of this, stated with the estimate: 85%); the middle value lies beyond the limit too.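

In this assay no step can be read among compound 2, compound 3 and compound 4, because each gives a limit and not a number: the limit of > 100000 nM in this assay, at which 3 of the 4 values shown sit. The compounds shown leave open how these three rank against one another, and how any of them compares with compound 1.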